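Amide-end variation on a shared core: three measured, one pending

This account rests on a few compounds, and the source may have more. Where it says the series, first, only, none or still open, it means among the compounds named here.

Values in a functional assay on KM12 cells (Homo sapiens) for inhibition, read by sulforhodamine B assay, with a stated time of 48 h (a higher number here means a weaker inhibitor of growth, a lower number a stronger inhibitor of growth), so far:
compound 1 `COc1cc(-c2nn(-c3cccc(NC(=O)c4cccc(C(F)(F)F)c4)c3)cc2-c2ccncc2)ccc1Cl`: 1660 nM
compound 2 `COc1cc(-c2nn(-c3cccc(NC(=O)c4ccc(Cl)c(C(F)(F)F)c4)c3)cc2-c2ccncc2)ccc1Cl`: 2060 nM
compound 3 `COc1cc(-c2nn(-c3cccc(NC(=O)Nc4ccc(Cl)c(C(F)(F)F)c4)c3)cc2-c2ccncc2)ccc1Cl`: 1060 nM

Compound 3 has the lowest of the three numbers, but its separation from the others is small: a 1.6-fold lower number from compound 1 to compound 3 (0.19 log units; within the scatter) and a 1.9-fold lower number from compound 2 to compound 3 (0.29 log units; within the scatter), both within the scatter, so no order among the three can be claimed. Within the data shown here, the one step that keeps the carbonyl carbon untouched, a 1.2-fold higher number from compound 1 to compound 2 (0.09 log units; within the scatter), is likewise within the scatter.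

Compound 4 `COc1cc(-c2nn(-c3cccc(NC(=O)c4ccccc4)c3)cc2-c2ccncc2)ccc1Cl` is the next member. Relative to compound 3 the change is phenyl in place of (4-chloro-3-(trifluoromethyl)phenyl)amino on a carbonyl carbon. Among the measured compounds shown here, the steps that bear on it are those at the same carbonyl carbon, a 1.6-fold lower number from compound 1 to compound 3 (0.19 log units; within the scatter) and a 1.9-fold lower number from compound 2 to compound 3 (0.29 log units; within the scatter), which were both small, and a 1.2-fold higher number from compound 1 to compound 2 (0.09 log units; within the scatter), which shows that adding chloro to the aromatic ring changed little. For the measured compounds named here, no measured step strips the ring of both its substituents at once, so the expectation rests on analogy only. A modest rise in the number is expected, a 2.4-fold higher number from compound 3 to compound 4 (0.37 log units; beyond the scatter), at most around the edge of the scatter. Compound 4 is therefore estimated at 2500 nM, with a range from 1000 nM to 6000 nM.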

Compound 4, concentration for 50% growth inhibition: 556 nM
The estimate for compound 4 lay 4.5-fold (0.65 log units) above the measured number; the measured number lies below the stated range.
By their numbers in this assay, from the lowest: compounds 4, 3, 1 and 2 (each within the scatter of the next, the first and the last beyond it).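

In this assay, steps at this carbonyl carbon now go beyond the scatter: phenyl in place of 4-chloro-3-(trifluoromethyl)phenyl gives a 3.7-fold lower number from compound 2 to compound 4 (0.57 log units; beyond the scatter) and, with hydrogen in place of trifluoromethyl on an aromatic carbon, the change gives a 3.0-fold lower number from compound 1 to compound 4 (0.48 log units; beyond the scatter). Neither substituent is therefore required for growth inhibition in this amide set, while phenyl in place of (4-chloro-3-(trifluoromethyl)phenyl)amino stays within the scatter, with a 1.9-fold lower number from compound 3 to compound 4 (0.28 log units; within the scatter) as the step. No measurement available here explains these steps.

Still open, from the compounds shown here alone, is whether a lone chloro, an amine or a carboxylic acid on the phenyl ring would keep the number of compound 4. Plain phenylamino on the carbonyl carbon would also test the amino link without the ring substituents.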